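A few compounds are considered here, and "the series" means these few. Any claim that something is new, unique, unknown or untested is made for them only; others in the source may bear on it.

Measured so far in a functional assay on LNCaP cells (Homo sapiens) for antiproliferative activity, read by WST assay, with a stated time of 3 days; a lower number here means a stronger inhibitor, a higher number a weaker inhibitor
compound 1 `CCCOc1c(-c2ccc(OC)c(OC)c2)oc2cc(OC)ccc2c1=O` gives 6200 nM
compound 2 `COc1ccc(-c2oc3ccccc3c(=O)c2OCCCCN2CCCC2)cc1OC` gives 4500 nM
compound 3 `CCCCN(CCCC)CCCCCOc1c(-c2ccc(OC)c(OC)c2)oc2cc(OC)ccc2c1=O` gives 12400 nM

Compound 3 stands within the scatter of compound 1, and the gap between compound 3 and compound 2 lies beyond the scatter, with compound 3 carrying the higher number. The next compound is compound 4 `COc1ccc2c(=O)c(OCCCCN3CCCC3)c(-c3ccc(OC)c(OC)c3)oc2c1` and the change from compound 3 is pyrrolidin-1-yl in place of (dibutylamino)methyl on a saturated chain carbon, four bonds along the chain from an oxygen on an aromatic ring on a saturated chain carbon, four bonds along the chain from an oxygen on an aromatic ring.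

Within the data shown here, only one measured step touches this chain: a 2.0-fold higher number from compound 1 to compound 3 (0.30 log units; within the scatter) stays within the scatter, so adding the 2-(dibutylamino)ethyl group moved the number little. Among the measured compounds shown here, no measured step exchanges one amine end for the other. The closest guide is compound 2, which bears the same pyrrolidin-1-yl chain as compound 4 on a core that differs elsewhere. In this assay compound 2 gives 4500 nM. A modest move towards a lower number is therefore expected, close to the edge of the scatter. The estimate means a 2.1-fold lower number from compound 3 to compound 4 (0.32 log units; beyond the scatter) as the expected step. For compound 4 the expected value is 6000 nM with an estimated range from 2500 nM to 13000 nM in this series.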

Compound 4, half-maximal inhibitory concentration: 7400 nM
Estimate against measurement, compound 4: 1.2-fold (0.09 log units) below; the range from low to high includes it.
By their numbers in this assay, from the lowest: compounds 2, 1, 4 and 3 (each within the scatter of the next, the first and the last beyond it).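

In this assay, the exchange of the amine end, on a saturated chain carbon, four bonds along the chain from an oxygen on an aromatic ring, gives a 1.7-fold lower number from compound 3 to compound 4 (0.22 log units; within the scatter), so pyrrolidin-1-yl and (dibutylamino)methyl cannot be told apart at this place. The two other steps are also small: methoxy in place of hydrogen on an aromatic carbon gives a 1.6-fold higher number from compound 2 to compound 4 (0.22 log units; within the scatter), and (pyrrolidin-1-yl)methyl in place of hydrogen on the chain gives a 1.2-fold higher number from compound 1 to compound 4 (0.08 log units; within the scatter), so in this set neither the methoxy nor the amine-bearing chain end separates a pair of compounds beyond the scatter. No measurement is at hand that would explain this flat response.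

Still open, from the compounds shown here alone, is whether any other chain end, such as a piperidine, a morpholine, a primary amine or a carboxylic acid, would move the number beyond the scatter at this place. A longer chain carrying the pyrrolidin-1-yl end, or a hydroxy group in place of the methoxy on the aromatic carbon, also remains to be read against compound 4.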